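Swapping hydrogen for dimethylamino on a shared core

The source may hold more compounds than are shown below. What is called first, only, known or untested is meant among the compounds shown, and "the series" means these compounds.

Of the compounds shown here, three sharing one core have been tested in a functional assay on aorta (Rattus norvegicus, strain Wistar) for inhibition, with a stated time of 60 min; a higher number here means a larger maximal response, a lower number a smaller maximal response. Compound 1 `FC(F)(F)c1ccc2[nH]c(-c3ccccc3)nc2c1` gives 91.2%. Compound 2 `O=[N+]([O-])c1ccccc1-c1nc2cc(C(F)(F)F)ccc2[nH]1` gives 93.2%, and compound 3 `CCOc1ccccc1-c1nc2cc(C(F)(F)F)ccc2[nH]1` gives 91%. Compound 1 thus sits among three numbers that all lie within the scatter of one another, so no order can be read among them. The two steps that start from compound 1 both attach a group to the same kind of aromatic carbon: a number 2 percentage points higher from compound 1 to compound 2 (within the scatter), and a number 0.2 percentage points lower from compound 1 to compound 3 (within the scatter). Neither attachment moved the maximal response beyond the scatter.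

Compound 4 `CN(C)c1ccc(-c2nc3cc(C(F)(F)F)ccc3[nH]2)cc1` differs from compound 1 in one place: dimethylamino in place of hydrogen on an aromatic carbon. Because the two measured steps from compound 1, a number 2 percentage points higher from compound 1 to compound 2 (within the scatter) and a number 0.2 percentage points lower from compound 1 to compound 3 (within the scatter), stayed within the scatter, a third group placed on an aromatic carbon is expected to behave alike, so the expected step is a number 0.2 percentage points lower from compound 1 to compound 4 (within the scatter), no change beyond the scatter. Compound 4 is therefore estimated at 91%, with a range from 83% to 98%.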

Compound 4, largest response reached (Emax), in percent of the reference or control that the assay uses: 63.2%
Estimate against measurement, compound 4: 27.8 percentage points above, and the stated range ends above it.
By their numbers in this assay, from the lowest: compound 4; then compounds 3, 1 and 2 (each within the scatter of the next).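

In this assay, placing dimethylamino on an aromatic carbon para to a large group gives a number 28 percentage points lower from compound 1 to compound 4 (beyond the scatter), the only step among these compounds that lies beyond the scatter. Attaching a group to the phenyl-bearing part of the shared core is therefore not neutral in every case, and the nitro and ethoxy steps, both within the scatter, gave no warning of this one. Nothing available here explains the drop in maximal response.

The compounds shown leave open whether the drop belongs to dimethylamino itself or to its place on the ring. A plain amine or a methoxy group on that same carbon, or dimethylamino on another carbon of the ring, would help to separate these two readings.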